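A furan swap without a measured precedent

This account rests on a few compounds, and the source may have more. Where it says the series, first, only, none or still open, it means among the compounds named here.

Measured so far in a functional assay on HCT-15 cells (Homo sapiens) for cytotoxicity, read by ELISA, with a stated time of 4 days; on this read-out higher numbers stand for weaker inhibition and lower numbers for stronger inhibition:
Compound 1 `Cc1ccc(-c2cc(-c3ccoc3)cc(-c3ccc(Cl)s3)n2)cc1` gives 1170 nM
Compound 2 `Clc1ccc(-c2cc(-c3ccoc3)cc(-c3ccccn3)n2)s1` gives 1270 nM
Compound 3 `Clc1ccc(-c2cc(-c3ccoc3)cc(-c3cccnc3)n2)s1` gives 720 nM

Compound 1 sits in a tight group of numbers. The data show a 1.1-fold higher number from compound 1 to compound 2 (0.04 log units; within the scatter) and a 1.6-fold lower number from compound 1 to compound 3 (0.21 log units; within the scatter), both within the scatter of repeated measurements, so the three values cannot be ranked.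

The next compound is compound 4 `Cc1ccc(-c2cc(-c3ccc(Cl)o3)cc(-c3ccc(Cl)s3)n2)cc1`, which differs from compound 1 at one place, opposite the ring nitrogen. The difference is 5-chlorofuran-2-yl in place of furan-3-yl on an aromatic carbon, with 5-chlorofuran-2-yl in place of furan-3-yl on an aromatic carbon.

For the measured compounds named here, none of the measured steps touches this place. All three compounds carry furan-3-yl, and their steps exchange only the 4-methylphenyl group and the two pyridinyl groups. Even the remaining step, a 1.8-fold lower number from compound 2 to compound 3 (0.25 log units; within the scatter), stays within the scatter. These steps show that changes elsewhere on the molecule moved the number little, but they say nothing direct about the new group. No direction can be argued from them, so no shift beyond the scatter is expected, although the uncertainty is wide.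

The estimated step is a 1.2-fold lower number from compound 1 to compound 4 (0.07 log units; within the scatter), which would be no real change. Compound 4 is expected at about 1000 nM, with an estimated range from 300 nM to 3300 nM in this measurement.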

Compound 4, half-maximal inhibitory concentration: > 50000 nM
Compound 4: only a limit was reported; the forecaster's own chance of this, stated with the estimate: 3%; middle value at least 50-fold (1.69 log units) from the limit.
By their numbers in this assay, from the lowest: compounds 3, 1 and 2 (each within the scatter of the next). At a limit, above all of these: compound 4.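

In this assay, compound 4 is reported only as a limit, > 50000 nM, and it is the only compound shown with such a reading: the limit of > 50000 nM in this assay, at which 1 of the 4 values shown sits.

Exchanging furan-3-yl for 5-chlorofuran-2-yl at the place opposite the ring nitrogen gives an at least 42-fold higher number from compound 1 to compound 4 (1.63 log units; beyond the scatter), the only step shown that lies beyond the scatter. The earlier steps shown here exchanged only the 4-methylphenyl group and the two pyridinyl groups, and they left the number within the scatter, so they gave no sign that the molecule could be this sensitive to a change at another place. Since higher numbers stand for weaker inhibition on this read-out, this change at this place weakens inhibition, a clear loss set against the flat picture of the first three compounds.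

The change does two things at once, moving the furan's point of attachment and adding a chlorine, and a plain furan-2-yl group at this place would be needed to tell these two apart. Also open, going by these compounds, is how a phenyl group or an amine at this place would read in this assay.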